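The source may hold more compounds than are shown below. What is called first, only, known or untested is meant among the compounds shown, and "the series" means these compounds.

Working notes on the series. In a functional assay on PC-3 cells (Homo sapiens) for antiproliferative activity, read by MTT assay, with a stated time of 48 h (on this read-out higher numbers stand for weaker inhibition of growth and lower numbers for stronger inhibition of growth), compound 3 (`CCCCN(Cc1ccc(C(=O)NO)cc1)c1ncc(-c2ccc(C)cc2)s1`) gives 6410 nM. Compound 1 (`CCCCCN(Cc1ccc(C(=O)NO)cc1)c1ncc(-c2ccc(C)cc2)s1`) gives 5060 nM. Compound 2 (`Cc1ccc(OCCCN(Cc2ccc(C(=O)NO)cc2)c2ncc(-c3ccc(C)cc3)s2)cc1`) gives 9330 nM. Compound 3 lies within the scatter of both other compounds, so these three values set no order.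

Compound 4 (`Cc1ccc(-c2cnc(N(Cc3ccc(C(=O)NO)cc3)C(C)C)s2)cc1`) differs from compound 3 in one place: isopropyl in place of butyl on a nitrogen on an aromatic ring.

All three measured steps concern the chain on that same nitrogen. The closest in kind is a 1.3-fold higher number from compound 1 to compound 3 (0.10 log units; within the scatter), which stays within the scatter. The step that brings in 4-methylphenoxy, a 1.8-fold higher number from compound 1 to compound 2 (0.27 log units; within the scatter), also stays within the scatter, as does its counterpart, a 1.5-fold lower number from compound 2 to compound 3 (0.16 log units; within the scatter). For the measured compounds named here, no measured compound carries isopropyl on this nitrogen, so the data do not test this group directly. With that caution, no step beyond the scatter is expected in this assay.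

The estimated step is a 1.0-fold higher number from compound 3 to compound 4 (0.01 log units; within the scatter). For compound 4, the expected value is 6500 nM, with an estimated range of 3000 nM to 14000 nM.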

Compound 4, concentration for 50% growth inhibition: 1150 nM
Compound 4: middle estimate off by 5.7-fold (0.75 log units), on the high side; the measured number lies below the stated range.
By their numbers in this assay, from the lowest: compound 4; then compounds 1, 3 and 2 (each within the scatter of the next).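

In this assay, the nitrogen on the aromatic ring turns out to respond to its substituent: with isopropyl in place of butyl there is a 5.6-fold lower number from compound 3 to compound 4 (0.75 log units; beyond the scatter), and the comparisons with the other two chains give a 4.4-fold lower number from compound 1 to compound 4 (0.64 log units; beyond the scatter) and an 8.1-fold lower number from compound 2 to compound 4 (0.91 log units; beyond the scatter). The butyl, pentyl and 3-(4-methylphenoxy)propyl compounds could not be ordered among themselves, so this position looked flat until isopropyl appeared, and compound 4 now shows the strongest inhibition of growth among the four, with each of its steps beyond the scatter. No supporting measurement is available to explain the difference.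

With a single branched group on this nitrogen, the result does not separate the effect of branching from that of the smaller carbon count, and a straight propyl or ethyl chain alongside a cyclopropyl or tert-butyl group would be needed to tell them apart. As far as these compounds go, it also remains open whether the same change would hold with a group other than the 4-methylphenyl substituent of the shared core, such as a 4-fluorophenyl group.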